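The source may report more compounds than this note shows. Statements on the series, on what has been measured and on what is new or still open speak of the compounds shown alone.

In a functional assay on MCF7 cells (Homo sapiens) for inhibition, read by MTT assay, with a stated time of 48 h (a lower number here means a stronger inhibitor, a higher number a weaker inhibitor), compound 1, `Cc1ccc(/C=C2\SC(=O)N(CCNC(=O)Nc3c(C)n(C)n(-c4ccccc4)c3=O)C2=O)cc1`, gives 37400 nM, while compound 2, `COc1ccc(/C=C2\SC(=O)N(CCNC(=O)Nc3c(C)n(C)n(-c4ccccc4)c3=O)C2=O)cc1`, gives 5140 nM, the lower of the two numbers. Compound 3, `Cc1c(NC(=O)NCCN2C(=O)S/C(=C\c3ccc([N+](=O)[O-])cc3)C2=O)c(=O)n(-c2ccccc2)n1C`, keeps the shared core and differs from compound 2 at a single place: nitro in place of methoxy on an aromatic carbon. The 4-methoxyphenyl of compound 2 thus becomes 4-nitrophenyl in compound 3.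

Within the data shown here, only one measured step bears on this change: a 7.3-fold lower number from compound 1 to compound 2 (0.86 log units; beyond the scatter), with methoxy in place of methyl at the same place. Among the measured compounds shown here, it shows that a change here can move the number beyond the scatter, but no measured compound carries nitro, so its size can serve only as a rough guide. For the measured compounds named here, a modest step toward a higher number is expected because compound 2 holds the lower of only two values at 5140 nM, though the direction remains uncertain. The estimated change is a 2.3-fold higher number from compound 2 to compound 3 (0.37 log units; beyond the scatter). For compound 3 the estimated value is 12000 nM, with an expected range from 2500 nM to 50000 nM.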

Compound 3, half-maximal inhibitory concentration: 18600 nM
Compound 3: the middle estimate sits 1.6-fold (0.19 log units) below what was measured, and the stated range covers the measured number.
By their numbers in this assay, from the lowest: compound 2; then compounds 3 and 1 (each within the scatter of the next).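

In this assay, putting nitro in place of methoxy on the aromatic carbon gives a 3.6-fold higher number from compound 2 to compound 3 (0.56 log units; beyond the scatter), so the earlier gain seen with methoxy is now matched by a loss when methoxy leaves, and this place in the molecule is shown to respond in both directions. Among these compounds, the second new comparison, a 2.0-fold lower number from compound 1 to compound 3 (0.30 log units; within the scatter), shows that nitro and methyl cannot be told apart here, which leaves methoxy as the only one of the three groups set off from both others by steps beyond the scatter. Nothing available here accounts for why methoxy stands apart from methyl and nitro.

Among the compounds shown here, with only three groups at this one place, it remains open whether the lower number belongs to methoxy alone or would also appear with a group such as ethoxy, hydroxy or a dimethylamino group. The compounds shown also leave open whether the same order of methoxy, nitro and methyl would hold if the phenyl on the shared core carried a chlorine, or if the two-carbon link were replaced by a longer chain.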